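The source may report more compounds than this note shows. Statements on the series, on what has been measured and on what is new or still open speak of the compounds shown alone.

Compound 3, with the structure `CS(=O)(=O)Nc1cccc(-c2nc(C(c3ccc(F)cc3)c3ccc(F)cc3)sc2CC(=O)O)c1`, is one of three measured compounds that share the same core. In an in vitro functional assay on HEK285-7 cells for antagonist activity at prostaglandin D2 receptor 2 (Homo sapiens), read by BRET and beta-arrestin recruitment (a lower number here means a smaller maximal response, a higher number a larger maximal response), compound 3 gives 80%. Compound 1, with the structure `O=C(O)Cc1sc(C(c2ccc(F)cc2)c2ccc(F)cc2)nc1-c1ccnc(N2CCCC2)c1`, gives 80% in this assay, and compound 2, with the structure `O=C(O)Cc1sc(C(c2ccc(F)cc2)c2ccc(F)cc2)nc1-c1ccoc1`, gives 80%. The three differ only in the group on one aromatic carbon of the core, and all three readings sit level: no change at the digits printed from compound 1 to compound 2 (within the scatter), no change at the digits printed from compound 1 to compound 3 (within the scatter) and no change at the digits printed from compound 2 to compound 3 (within the scatter). So compound 3 stands neither above nor below its two neighbours.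

Compound 4, with the structure `O=C(O)Cc1sc(C(c2ccc(F)cc2)c2ccc(F)cc2)nc1-c1ccnc(O)c1`, keeps the core and changes that same group once more: 2-hydroxypyridin-4-yl in place of 3-(methanesulfonamido)phenyl on an aromatic carbon. The change sits on an aromatic carbon of a five-membered aromatic ring with one nitrogen and one sulfur, next to the ring nitrogen and next to the ring atom that bears a carboxymethyl group.

All three measured steps bear on this change, since each swaps the group at this very place, and none moved the maximal response beyond the scatter. The step from compound 3 to compound 4 is therefore expected to be no change at the digits printed from compound 3 to compound 4 (within the scatter), no change beyond the scatter. For compound 4 the expected value in this assay is 80%, within a range from 70% to 90%.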

Compound 4, largest response reached (reported as efficacy), in percent of the reference or control that the assay uses: 60%
Compound 4: the middle estimate sits 20 percentage points above what was measured; the measured number lies below the stated range.
By their numbers in this assay, from the lowest: compound 4; then compounds 1, 2 and 3 (each within the scatter of the next).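

This position is not indifferent to the group it carries. Swaps among the first three groups left the reading level in this assay, but 2-hydroxypyridin-4-yl gives a number 20 percentage points lower from compound 3 to compound 4 (beyond the scatter), and against the furan-3-yl compound it gives a number 20 percentage points lower from compound 2 to compound 4 (beyond the scatter). The closest comparison is a number 20 percentage points lower from compound 1 to compound 4 (beyond the scatter), where the pyridin-4-yl part stays and only hydroxy takes the place of pyrrolidin-1-yl, so having that part alone does not bring the lower reading, and what it carries matters; nothing measured here accounts for this drop.

The compounds shown carry only pyrrolidin-1-yl and hydroxy on the pyridin-4-yl part, so it remains open whether a methoxy group or a plain amine there would stay level with compound 1 or fall with compound 4. Also open, as far as these compounds go, is whether hydroxy lowers the reading only on the pyridin-4-yl part, which a 3-hydroxyphenyl group in place of 3-(methanesulfonamido)phenyl would test.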